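Moving the methyl on the urea phenyl of compound 2

The source may report more compounds than this note shows. Statements on the series, on what has been measured and on what is new or still open speak of the compounds shown alone.

Of the compounds shown here, two have been measured so far in a functional assay on A549 cells (Homo sapiens) for antiproliferative activity, read by MTT assay; on this read-out lower numbers stand for stronger inhibition and higher numbers for weaker inhibition. Compound 1 `Cc1ccccc1NC(=O)Nc1cccc(CNc2ncnc3ccccc23)c1` gives 40200 nM in this assay, and compound 2 `COc1cc2ncnc(NCc3cccc(NC(=O)Nc4ccccc4C)c3)c2cc1OC` gives 21400 nM. Of these two numbers, that of compound 2 is the smaller, but the gap to compound 1 lies within the usual scatter, so the two cannot be told apart on this evidence.

Compound 3 `COc1cc2ncnc(NCc3cccc(NC(=O)Nc4ccc(C)cc4)c3)c2cc1OC` differs from compound 2 only in 4-methylphenyl in place of 2-methylphenyl on an amide-type nitrogen. For the measured compounds named here, no pair of measured compounds shows what such a move of the methyl does in this assay, so there is nothing to read a direction from. The expectation for compound 3 is therefore a step from compound 2 of about a 1.1-fold lower number from compound 2 to compound 3 (0.03 log units; within the scatter), that is, none beyond the scatter. Compound 3 is accordingly estimated at 20000 nM in this assay, with a range from 6000 nM to 65000 nM.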

Compound 3, half-maximal inhibitory concentration: 12900 nM
Compound 3: the middle estimate sits 1.6-fold (0.19 log units) above what was measured, and the stated range covers the measured number.
By their numbers in this assay, from the lowest: compounds 3, 2 and 1 (each within the scatter of the next, the first and the last beyond it).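

For the compounds shown here, this step gives the only reading so far of a change at this place: with the rest of the molecule held fixed, 4-methylphenyl in place of 2-methylphenyl on an amide-type nitrogen gives a 1.7-fold lower number from compound 2 to compound 3 (0.22 log units; within the scatter) in this assay. On this evidence, the move of the methyl does not separate compound 2 from compound 3 on this read-out, so the two methylphenyl groups cannot be told apart here. Nothing available explains the size of this step or bears on it.

From the compounds shown here alone, it remains open whether a chlorine atom, a methoxy group, a trifluoromethyl group or a carboxylic acid in place of the methyl would give a step beyond the scatter. Going by these compounds, it is equally open whether the same move of the methyl on the core of compound 1 would behave in the same way.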